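Acyl Group on the Ring Nitrogen of the Anilide Core

This account rests on a few compounds, and the source may have more. Where it says the series, first, only, none or still open, it means among the compounds named here.

Measured so far in a functional assay on HCT-15 cells (Homo sapiens) for cytotoxicity, read by sulforhodamine B assay, with a stated time of 72 h; a higher number here means a weaker inhibitor of growth, a lower number a stronger inhibitor of growth:
compound 1 `O=C(Nc1ccccc1C(F)(F)F)C1CCc2ccccc2N1` gives 40400 nM;
compound 2 `O=C(Nc1ccccc1O)C1CCc2ccccc2N1` gives 5610 nM;
compound 3 `O=C(Nc1ccccc1)C1CCc2ccccc2N1` gives 109000 nM.

Among these three numbers compound 1 stands second highest. Its nearest neighbour is compound 3, reached by a 2.7-fold higher number from compound 1 to compound 3 (0.43 log units; beyond the scatter); its furthest is compound 2, reached by a 7.2-fold lower number from compound 1 to compound 2 (0.86 log units; beyond the scatter). Between the two others the gap is a 19-fold higher number from compound 2 to compound 3 (1.29 log units; beyond the scatter). Every one of these measured steps exchanges the small group on the aromatic carbon of the anilide ring; none of them alters the ring nitrogen of the shared core, which in all three compounds still carries a hydrogen.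

For the measured compounds named here, compound 4 `O=C(Nc1ccccc1C(F)(F)F)C1CCc2ccccc2N1C(=O)c1ccccc1Cl` is the first to change that nitrogen: (2-chlorophenyl)carbonyl in place of hydrogen on a nitrogen on an aromatic ring in a ring. Going by the values given here, no measured step bears on this kind of change, so the three steps above cannot be read across to it, and the data give no hint of its direction. The only fixed point is the value of compound 1, which serves as the anchor. Compound 4 is therefore expected, with wide uncertainty, to give about 15000 nM, somewhere between 3000 nM and 80000 nM. That estimate corresponds to an expected step of a 2.7-fold lower number from compound 1 to compound 4 (0.43 log units; beyond the scatter).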

Compound 4, concentration for 50% growth inhibition: 4220 nM
Compound 4: the middle estimate sits 3.6-fold (0.55 log units) above what was measured, and the stated range covers the measured number.
By their numbers in this assay, from the lowest: compounds 4 and 2 (each within the scatter of the next); then compound 1; then compound 3.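

In this assay, the ring nitrogen of the shared core proves to be a second place where a change alters the number: (2-chlorophenyl)carbonyl in place of hydrogen gives a 9.6-fold lower number from compound 1 to compound 4 (0.98 log units; beyond the scatter) and so strengthens growth inhibition. The earlier compounds shown here varied only the small group on the anilide ring, so they could not show that this nitrogen can give up its hydrogen and take a much larger group, one with 9 heavy atoms and its own aromatic ring, without loss of growth inhibition in this pair. No measurement shown here explains why the number falls.

From the compounds shown here alone, it remains open which part of the entering group matters, and whether a smaller acetyl group, a plain benzoyl group without chlorine, or a simple methyl group on the same nitrogen would give a similar step. Going by these compounds, it is also open whether the effect at this nitrogen would hold with hydroxy rather than trifluoromethyl on the anilide ring, since a single pair of compounds cannot show whether the two changes add up.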